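Cyclopropylamide in Place of Carboxylic Acid on a Shared Core

A few compounds are considered here, and "the series" means these few. Any claim that something is new, unique, unknown or untested is made for them only; others in the source may bear on it.

Compound 2 `O=C(O)/C=C/c1ccncc1-c1ccc2ccccc2c1` carries a carboxy group at the end of its ethenyl chain. In a functional assay on HCT-116 cells (Homo sapiens) for inhibition, read by MTT assay, with a stated time of 72 h (on this read-out lower numbers stand for stronger inhibition of growth and higher numbers for weaker inhibition of growth), compound 2 gives > 30000 nM, and this is a limit of the assay rather than a measured number. Two further compounds on a related core, compound 1 `CNC(=O)/C=C/c1ccncc1-c1ccc2cccnc2c1` and compound 3 `Cn1ccc2cc(-c3cnccc3/C=C/C(=O)N3CCOCC3)ccc21`, both amides, have no result in this assay: compound 1 gives "not determined" (no result reported) and compound 3 gives "not determined" (no result reported). Compound 2 therefore stands alone, and all that is known of it is the limit of > 30000 nM in this assay, at which 1 of the 3 values shown sits.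

Compound 4 `O=C(/C=C/c1ccncc1-c1ccc2ccccc2c1)NC1CC1` is the compound still to be measured. It differs from compound 2 in one place (cyclopropylamino in place of hydroxy on a carbonyl carbon). For the measured compounds named here, no measured pair shows what such a change does on this core, so the step can only be guessed from the change itself. Compound 2 sits at a limit, and any measurable number for compound 4 would count as a gain. The step of an at least 10-fold lower number from compound 2 to compound 4 (1.00 log units; beyond the scatter) is expected to be a large gain, with a second limit still a real possibility. Compound 4 is estimated at 3000 nM, within a range from 300 nM to 30000 nM.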

Compound 4, concentration for 50% growth inhibition: 6180 nM
Beside the measured number, compound 4's estimate is 2.1-fold (0.31 log units) below it; the measured number falls inside the stated range.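

On the shared core, the change at the carbonyl carbon now has a first readable result: in this assay, cyclopropylamino in place of hydroxy gives an at least 4.8-fold lower number from compound 2 to compound 4 (0.68 log units; beyond the scatter). This step lies beyond the usual scatter, and it shows that a compound with cyclopropylcarbamoyl in place of carboxy can give a measured number on this core, which compound 2 alone could not show. The printed step is only a minimum, and its true size stays unknown because compound 2 stands at a limit: the limit of > 30000 nM in this assay, at which 1 of the 4 values shown sits.

The compounds shown leave open whether the three-membered ring itself matters, or whether an open-chain isopropylamino group on the same carbonyl carbon would give a similar number. They also leave open how a methyl ester at this place would compare on the same core.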